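The source may hold more compounds than are shown below. What is called first, only, known or untested is meant among the compounds shown, and "the series" means these compounds.

Measured so far:
compound 1, `Cc1ccccc1Nc1nc(Nc2cccnc2)ncc1Cl`, gives 56500 nM in a functional assay on MCF7 cells (Homo sapiens) for inhibition, read by CCK-8 assay, with a stated time of 48 h; on this read-out higher numbers stand for weaker inhibition of growth and lower numbers for stronger inhibition of growth
compound 2, `Cc1ccccc1Nc1nc(Nc2ccccn2)ncc1Cl`, gives 31400 nM in this assay

Both compounds share one core and differ only in the group carried on a nitrogen on an aromatic ring. Among the measured compounds shown here, compound 1 holds the higher of the two numbers, but the single measured step, a 1.8-fold lower number from compound 1 to compound 2 (0.26 log units; within the scatter), so the two compounds cannot be told apart on these data.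

Compound 3, `Cc1ccccc1Nc1nc(NCc2ccncc2)ncc1Cl`, has not yet been measured. It differs from compound 1 in one place: (pyridin-4-yl)methyl in place of pyridin-3-yl on a nitrogen on an aromatic ring. For the measured compounds named here, the only measured step that touches the same position is the one from compound 1 to compound 2, and that step stayed within the scatter. The change leading to compound 3 is of a somewhat different kind, since a (pyridin-4-yl)methyl group enters where pyridin-3-yl leaves, yet nothing measured points in either direction. The expected step is therefore a 1.1-fold lower number from compound 1 to compound 3 (0.05 log units; within the scatter), nothing beyond the scatter. Compound 3 is accordingly estimated at 50000 nM, with a range from 15000 nM to 160000 nM.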

Compound 3, concentration for 50% growth inhibition: > 100000 nM
Compound 3 ended at the assay's limit; the forecaster's own chance of this, stated with the estimate: 25%; at least 2.0-fold (0.30 log units) between middle value and limit.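

In this assay compound 3 gives > 100000 nM and this is a limit of the assay, not a number. Among the compounds shown here, it brings the first change at this position on a nitrogen on an aromatic ring that can be told from the scatter, namely an at least 3.1-fold higher number from compound 2 to compound 3 (0.50 log units; beyond the scatter) in the direction of weaker inhibition of growth, so the group held here can matter even though swapping one directly attached pyridine ring for another gave no readable difference. The comparison with the other directly attached ring is less firm, with an at least 1.7-fold higher number from compound 1 to compound 3 (0.24 log units; that floor lies within the scatter) and a floor that does not clear the scatter, and the real size of both steps stays unknown because compound 3 sits at a limit: the limit of > 100000 nM in this assay, at which 1 of the 3 values shown sits.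

The change to compound 3 alters two things at once, since it adds a methyl link and also replaces the pyridin-2-yl or pyridin-3-yl ring with a pyridin-4-yl ring, and the compounds shown cannot separate these two parts. A (pyridin-3-yl)methyl group would hold the ring of compound 1 while adding the link, and a directly attached pyridin-4-yl group would hold the ring of compound 3 without it, so either could show which part goes with the loss.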